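The source may hold more compounds than are shown below. What is called first, only, known or untested is meant among the compounds shown, and "the series" means these compounds.

In a functional assay on A-375 cells (Homo sapiens) for cytotoxicity, read by MTT assay (on this read-out lower numbers stand for stronger inhibition and higher numbers for weaker inhibition), compound 2 `C=CC(=O)Oc1cc(/C=C/C(=O)c2ccc(OC)c3c2OC(C)(C)C=C3)ccc1OC` gives 390 nM and compound 1 `CCCCC(=O)Oc1cc(/C=C/C(=O)c2ccc(OC)c3c2OC(C)(C)C=C3)ccc1OC` gives 220 nM, so these two numbers lie within the scatter of each other. Compound 3 `COc1ccc(/C=C/C(=O)c2ccc(OC)c3c2OC(C)(C)C=C3)cc1OC(=O)C1CC1` differs from compound 2 as follows: cyclopropyl in place of vinyl on a carbonyl carbon. Going by the values given here, the only measured step that bears on this place is a 1.8-fold higher number from compound 1 to compound 2 (0.25 log units; within the scatter), with vinyl in place of butyl on a carbonyl carbon. On that evidence, no change beyond the scatter is expected in this assay. The estimated step is a 1.3-fold lower number from compound 2 to compound 3 (0.11 log units; within the scatter). For compound 3 the estimated value is 300 nM, with an expected range of 130 nM to 700 nM.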

Compound 3, half-maximal inhibitory concentration: 380 nM
Beside the measured number, compound 3's estimate is 1.3-fold (0.10 log units) below it; measured number inside the range.
By their numbers in this assay, from the lowest: compounds 1, 3 and 2 (each within the scatter of the next).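

In this assay, cyclopropyl in place of vinyl on a carbonyl carbon gives a 1.0-fold lower number from compound 2 to compound 3 (0.01 log units; within the scatter), and cyclopropyl in place of butyl gives a 1.7-fold higher number from compound 1 to compound 3 (0.24 log units; within the scatter). At this position, a three-membered ring therefore joins the two open chains with no step beyond the scatter, so compounds 1, 2 and 3 cannot be separated here. Nothing available explains this result.

Going by these compounds, whether an amine, a carboxylic acid or a chain longer than butyl at this position would move the number beyond the scatter remains open. Also open, on these data alone, is whether this flat picture holds on other cell lines.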